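Replacing methyl with (trifluoromethyl)carbonyl on the shared core

A few compounds are considered here, and "the series" means these few. Any claim that something is new, unique, unknown or untested is made for them only; others in the source may bear on it.

In a functional assay on MCF7 cells (Homo sapiens) for inhibition, read by radiometric assay and XTT assay (on this read-out lower numbers stand for stronger inhibition and higher numbers for weaker inhibition), compound 1 (`CCCCCCCC[C@@]1(C)SC(O)=C(C)C1=O`) gives 48 ug/mL and stands highest of the two measured compounds. Compound 2 (`CCCCCCCC[C@@]1(C)SC(=O)C=C1OC`) gives 16.4 ug/mL in this assay as a lower number, and the gap lies beyond the usual scatter. Compound 3 (`CCCCCCCC[C@@]1(C)SC(O)=C(C(=O)C(F)(F)F)C1=O`) keeps the core of compound 1 but carries (trifluoromethyl)carbonyl in place of methyl on a double-bonded ring carbon. Going by the values given here, no measured pair isolates a change at this place, so the data give no direct guide to its size. A modest step toward a lower number is expected, near the edge of the scatter, and no step beyond the scatter remains possible. The expected step is a 1.9-fold lower number from compound 1 to compound 3 (0.28 log units; within the scatter) in this assay as a tentative call. For compound 3 the estimated value is 25 ug/mL with 8 ug/mL to 75 ug/mL as the expected range.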

Compound 3, half-maximal inhibitory concentration: 18.4 ug/mL
Beside the measured number, compound 3's estimate is 1.4-fold (0.13 log units) above it, within the range that was stated.
By their numbers in this assay, from the lowest: compounds 2 and 3 (each within the scatter of the next); then compound 1.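

In this assay, going by these compounds alone, (trifluoromethyl)carbonyl in place of methyl on a double-bonded ring carbon gives a 2.6-fold lower number from compound 1 to compound 3 (0.42 log units; beyond the scatter), the first step that isolates a change at this place. The position therefore accepts a group of 6 heavy atoms in place of 1 without loss of inhibition, and the read-out responds to the exchange, moving toward stronger inhibition. Nothing at hand bears on the reason for this step, so it stands as an observation only.

Still open, on these data alone, is whether the step belongs to the carbonyl or to the trifluoromethyl part: an acetyl group and a lone trifluoromethyl group at this place would separate the two. Also open, as far as these compounds go, is whether the step persists when the group of 8 heavy atoms gives way to a shorter chain.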